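Swapping a Propyl Tail for a Methoxyphenyl Ring

This account rests on a few compounds, and the source may have more. Where it says the series, first, only, none or still open, it means among the compounds named here.

Compound 1, `CCCCOc1c(OC)c(OC)cc2c1C(=O)[C@]1(OC)C=C[C@H]2N(C(=O)OC)N1C(=O)OC`, was tested in an ADME assay on KB cells (Homo sapiens) for cytotoxicity; a lower number here means that less compound is needed, a higher number that more compound is needed for the effect. In this assay compound 1 gives > 300 ug/mL, which is a limit of the assay rather than a number. Compound 2, `CCCOc1c(OC)c(OC)cc2c1C(=O)[C@]1(OC)C=C[C@H]2N(C(=O)OCC)N1C(=O)OCC`, also ends at a limit: in this assay compound 2 gives > 300 ug/mL. Compound 1 thus sits at the limit, as the limit of > 300 ug/mL in this assay, at which 2 of the 2 values shown sit, shows. Compound 3, `COC(=O)N1[C@@H]2C=C[C@@](OC)(C(=O)c3c2cc(OC)c(OC)c3OCc2ccc(OC)cc2)N1C(=O)OC`, differs from compound 1 by 4-methoxyphenyl in place of propyl on a saturated chain carbon bound to an oxygen on an aromatic ring. Going by the values given here, no measured step is at hand. The step of a number no higher from compound 1 to compound 3 (the limit leaves the size open) is expected to be none beyond the scatter. Compound 3 is expected at 300 ug/mL, within 100 ug/mL to 600 ug/mL.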

Compound 3, concentration for half-maximal effect: > 300 ug/mL
Compound 3 ended at the assay's limit (the forecaster's own chance of this, stated with the estimate: 70%); the middle value sits exactly at the limit.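

Compound 1 and compound 3 both end at a limit of the assay rather than a number, so no step between them can be read: the limit of > 300 ug/mL in this assay, at which 3 of the 3 values shown sit.

The compounds shown leave open how much of each is needed for the effect in this assay, and whether 4-methoxyphenyl in place of propyl changes that amount.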